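This account rests on a few compounds, and the source may have more. Where it says the series, first, only, none or still open, it means among the compounds named here.

Three ureas built on the same core have been tested in an ADME assay on the whole organism with Oryza sativa as the target, tested at 10 uM; a higher number here means a weaker effect of the compound at the concentration tested, a lower number a stronger effect. Compound 1 `C[C@H](NC(=O)Nc1ccccc1C(F)(F)F)c1ccccc1` gives 97%. Compound 2 `C[C@H](NC(=O)Nc1ccccc1F)c1ccccc1` gives 65%. Compound 3 `C[C@@H](NC(=O)Nc1cccc(F)c1F)c1ccccc1` gives 90%. The step of a number 32 percentage points higher from compound 2 to compound 1 (beyond the scatter) comes from trifluoromethyl in place of fluoro on an aromatic carbon, a change made on an aromatic carbon ortho to a large group. The difference between the cores of compound 2 and compound 3 is not broken down here. Compound 4 `C[C@@H](NC(=O)Nc1cccc(C(F)(F)F)c1F)c1ccccc1` is not yet measured; it arises from compound 3 by trifluoromethyl in place of fluoro on an aromatic carbon, the same kind of change, but here ortho to a fluoro group and meta to a large group. Because compound 3 already stands at 90%, the step is expected to be smaller than the earlier one, about a number 6 percentage points higher from compound 3 to compound 4 (within the scatter). The estimate for compound 4 in this assay is 96%.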

Compound 4, a percentage reported as activity, at one concentration (the size of the read-out at that concentration, not a potency): 98%
Estimate against measurement, compound 4: 2 percentage points below, within the range that was stated.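

In this assay, among these compounds, trifluoromethyl in place of fluoro gives a number 8 percentage points higher from compound 3 to compound 4 (within the scatter) and so leaves no step that can be told from the scatter on this core. The same change therefore does not carry over at one size from one core to the other: the same change on two cores in this assay, a number 32 percentage points higher (beyond the scatter) from compound 2 to compound 1 and a number 8 percentage points higher (within the scatter) from compound 3 to compound 4, 24 percentage points apart, beyond the scatter of two such steps. This does not show why the two steps differ, and two cores give no rule for how the change would behave on a further core in this series.

The compounds shown vary only between fluoro and trifluoromethyl at the changing place, so it stays open how a chlorine, a methoxy group or an amine there would read in this assay. As far as these compounds go, it also stays open which of the differences between the two cores sets the size of the step.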